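The source may hold more compounds than are shown below. What is called first, only, known or untested is meant among the compounds shown, and "the series" means these compounds.

Compound 1 `CCCCCCNC(=O)CCCSC[C@H](NC(=O)OCc1ccccc1)C(=O)Nc1ccccc1` carries a hexyl chain on the amide nitrogen of its side chain. In an assay for inhibition of NAD-dependent protein deacylase sirtuin-6 (Homo sapiens), read by HPLC, with stated times of 15 min and 1 h, tested at 333 uM (on this read-out lower numbers stand for less inhibition and higher numbers for more inhibition at the one concentration tested (going by the name of the read-out)), compound 1 gives "not active" (no number reported), with no number attached, so it has no single figure to stand on. Two companions share the core of compound 1. Compound 2 `O=C(O)CCCNC(=O)CCCSC[C@H](NC(=O)OCc1ccccc1)C(=O)Nc1ccccc1` gives 35% in this assay. Compound 3 `CCNC(=O)CCCSC[C@H](NC(=O)OCc1ccccc1)C(=O)Nc1ccccc1`, with an ethyl group in place of the longer chain, gives 15% in this assay. For the measured compounds named here, the only step measured between these, a number 20 percentage points lower from compound 2 to compound 3 (beyond the scatter), replaces a carboxymethyl by hydrogen and is not the change followed here, so no measured step bears on it directly. Compound 4 `CNC(=O)CCCSC[C@H](NC(=O)OCc1ccccc1)C(=O)Nc1ccccc1` differs from compound 1 by hydrogen in place of pentyl on a saturated chain carbon bound to an amide-type nitrogen. What compound 1 and compound 3 show is that a hexyl chain gives no reportable inhibition while an ethyl chain gives a small one. On that basis compound 4 is expected to show at most weak inhibition, and its estimated value in this assay is 10%, within a range of 0% to 25%, with a real chance that only inactivity is reported.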

Compound 4, a percentage reported as inhibition, at one concentration (the size of the read-out at that concentration, not a potency): "not active" (no number reported)
Compound 4: no number reported; no gap can be computed for the estimate.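

Compound 1 and compound 4 both come without a number in this assay, so no step can be read between them. Nothing shown offers an explanation for this result. The compounds shown leave open how inhibition varies with the length of the chain on the amide nitrogen.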